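Lengthening the chain to the second imide arm

A few compounds are considered here, and "the series" means these few. Any claim that something is new, unique, unknown or untested is made for them only; others in the source may bear on it.

Compound 1 `Cc1c(C)c(S(=O)(=O)N(CCCCCN2C(=O)c3ccccc3C2=O)OCCCN2C(=O)c3ccccc3C2=O)c(C)c2c1OC(C)(C)CC2` carries two imide-bearing arms on a sulfonamide nitrogen. Going by the values given here, in a functional assay on IGROV-1 cells (Homo sapiens) for inhibition (a higher number here means a weaker inhibitor of growth, a lower number a stronger inhibitor of growth), compound 1 gives 3270 nM, and it stands level with its only measured neighbour, compound 2 `Cc1c(C)c(S(=O)(=O)N(CCCCN2C(=O)c3ccccc3C2=O)OCCCN2C(=O)c3ccccc3C2=O)c(C)c2c1OC(C)(C)CC2`, which in this assay gives 3270 nM. The step from compound 1 to compound 2 shortens one arm and brings no change at the digits printed from compound 1 to compound 2 (within the scatter).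

Compound 3 `Cc1c(C)c(S(=O)(=O)N(CCCCCCN2C(=O)c3ccccc3C2=O)OCCCN2C(=O)c3ccccc3C2=O)c(C)c2c1OC(C)(C)CC2` goes the other way: a group of 12 heavy atoms (9 carbon, 1 nitrogen, 2 oxygen; one five-membered non-aromatic ring with 1 hetero atom, one six-membered aromatic ring of carbon only) in place of a group of 11 heavy atoms (8 carbon, 1 nitrogen, 2 oxygen; one five-membered non-aromatic ring with 1 hetero atom, one six-membered aromatic ring of carbon only), on a saturated chain carbon, five bonds along the chain from a sulfonamide nitrogen. Among the compounds with values here, the only measured step that bears on this change is the shortening from compound 1 to compound 2, which left the growth inhibition unmoved within the scatter. Lengthening the same arm by one further carbon is therefore expected to produce no step beyond the scatter, written as a 1.0-fold higher number from compound 1 to compound 3 (0.00 log units; within the scatter). For compound 3 in this assay the estimate is 3300 nM, with a likely range from 1600 nM to 7000 nM.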

Compound 3, concentration for 50% growth inhibition: 3270 nM
Beside the measured number, compound 3's estimate is 1.0-fold (0.00 log units) above it, within the range that was stated.
By their numbers in this assay, from the lowest: compounds 1, 2 and 3 (each within the scatter of the next).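

With compound 3 in hand, this arm has been changed in both directions from compound 1, not only shortened. In this assay, adding the carbon brings no change at the digits printed from compound 1 to compound 3 (within the scatter), so the longer arm matches the shorter one in showing no readable shift. Across compounds 1, 2 and 3, the length of this chain therefore makes no difference that can be read in growth inhibition, and nothing available explains this flat result.

The compounds shown leave open whether a much longer or much shorter chain at this place would still give the same reading. They also leave open what would happen if an amine or a carboxylic acid stood at the end of this arm in place of the imide group.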